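The source may hold more compounds than are shown below. What is called first, only, known or untested is meant among the compounds shown, and "the series" means these compounds.

Measured compounds in this series:

compound 1, `CCn1c(C(=O)N[C@@H](C)C(=O)OC)ccc1C(CC)(CC)c1ccc(OCS(=O)(=O)c2ccccc2)c(C)c1` — 17900 nM
compound 2, `CCn1c(C(=O)NCC(=O)OC)ccc1C(CC)(CC)c1ccc(OCS(=O)(=O)c2ccccc2)c(C)c1` — 20000 nM
compound 3, `CCn1c(C(=O)N[C@@H](C)C(=O)O)ccc1C(CC)(CC)c1ccc(OCS(=O)(=O)c2ccccc2)c(C)c1` — 20800 nM

All three were run in a functional assay on BXPC-3 cells (Homo sapiens) for antiproliferative activity, read by MTT assay, with a stated time of 24 h; a lower number here means a stronger inhibitor, a higher number a weaker inhibitor. The three numbers sit close together: a 1.1-fold higher number from compound 1 to compound 2 (0.05 log units; within the scatter), a 1.2-fold higher number from compound 1 to compound 3 (0.07 log units; within the scatter), and a 1.0-fold higher number from compound 2 to compound 3 (0.02 log units; within the scatter). None of these steps stands out from the scatter.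

Compound 4, `CCn1c(C(=O)NCC(=O)O)ccc1C(CC)(CC)c1ccc(OCS(=O)(=O)c2ccccc2)c(C)c1`, has not yet been measured in this assay. It differs from compound 3 by hydrogen in place of methyl on a saturated chain carbon bound to an amide-type nitrogen and a carbonyl carbon. The same change has already been made once in the series, from compound 1 to compound 2, as hydrogen in place of methyl on a saturated chain carbon bound to an amide-type nitrogen and a carbonyl carbon, where it gave a 1.1-fold higher number from compound 1 to compound 2 (0.05 log units; within the scatter). The two places carry the same wording, so this is the same change. The two cores, that of compound 1 and that of compound 3, differ by hydrogen in place of methyl on an oxygen next to a carbonyl group.

Given that the earlier instance of this change left the number essentially unmoved, and that compound 3 itself sits within the scatter of compound 2, the step from compound 3 to compound 4 is expected to be small, about a 1.1-fold higher number from compound 3 to compound 4 (0.02 log units; within the scatter). The estimate for compound 4 in this assay is therefore 22000 nM, with a likely range from 12000 nM to 40000 nM.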

Compound 4, half-maximal inhibitory concentration: > 50000 nM
Compound 4: no number, only a limit; the forecaster's own chance of this, stated with the estimate: 10%; middle value at least 2.2-fold (0.35 log units) from the limit.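

In this assay compound 4 gives > 50000 nM as a limit of the assay and not as a number. Hydrogen in place of methyl on the saturated chain carbon gives an at least 2.4-fold higher number from compound 3 to compound 4 (0.38 log units; beyond the scatter) on the core of compound 3, but this does not show that the change acts differently on the two cores: the same change on two cores in this assay, a 1.1-fold higher number (0.05 log units; within the scatter) from compound 1 to compound 2 and an at least 2.4-fold higher number (0.38 log units; beyond the scatter) from compound 3 to compound 4; the limit leaves it open whether they differ. The remaining steps, an at least 2.5-fold higher number from compound 2 to compound 4 (0.39 log units; beyond the scatter) and an at least 2.7-fold higher number from compound 1 to compound 4 (0.44 log units; beyond the scatter), also rest on the limit, and the change from methyl ester to carboxylic acid stays equally undecided across the two cores: the same change on two cores in this assay, a 1.2-fold higher number (0.07 log units; within the scatter) from compound 1 to compound 3 and an at least 2.5-fold higher number (0.39 log units; beyond the scatter) from compound 2 to compound 4; the limit leaves it open whether they differ.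

On these data alone, how far the true value of compound 4 lies past the limit remains open, and with it the size of the step on this core. The compounds shown also leave open whether an ethyl group on that chain carbon, or a primary amide in place of the carboxylic acid, would keep the number close to that of compound 3.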